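A few compounds are considered here, and "the series" means these few. Any claim that something is new, unique, unknown or untested is made for them only; others in the source may bear on it.

Measured compounds in this series:
- compound 1, `CC(C)Cn1c(=O)n(C)c(=O)c2nc([S+]([O-])CCCO)c(Cc3cccc4ccccc34)nc21`: "not determined" (no result reported)
- compound 2, `CC(C)Cn1c(=O)n(C)c(=O)c2nc(S(=O)(=O)CCCO)c(Cc3cccc4ccccc34)nc21`: "not determined" (no result reported)
- compound 3, `CC(C)Cn1c(=O)n(C)c(=O)c2nc(CCCCO)c(Cc3cccc4ccccc34)nc21`: > 2000 nM

Three entries carry the shared core, the isobutyl and methyl groups and the naphthylmethyl arm, and differ in the side chain that ends in a hydroxyl. In an assay on MCF7 cells for inhibition of Monocarboxylate transporter 1 (Homo sapiens), read by scintillation counting, with a stated time of 10 min (a lower number here means a stronger inhibitor, a higher number a weaker inhibitor), compound 1 gives "not determined" (no result reported), and compound 2 gives "not determined" (no result reported). Compound 3 is the only one with a figure, and that figure is a limit of the assay rather than a number: compound 3 reaches only > 2000 nM. Compound 3 thus stands at the limit of > 2000 nM in this assay, at which 1 of the 3 values shown sits, and nothing among the three entries places it anywhere more exact.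

Compound 4, `CC(C)Cn1c(=O)n(C)c(=O)c2nc(CCCCCO)c(Cc3cccc4ccccc34)nc21`, is the next entry to be measured. It differs from compound 3 by hydroxymethyl in place of hydroxy on a saturated chain carbon, four bonds along the chain from an aromatic carbon, in words hydroxymethyl in place of hydroxy on a saturated chain carbon, four bonds along the chain from an aromatic carbon. Within the data shown here, no step between measured compounds in this assay is available, so there is no measured precedent for lengthening this chain.

With only a limit for compound 3, the expectation for compound 4 is a step that the limit leaves unreadable from compound 3 to compound 4, not beyond the scatter and in no clear direction. Compound 4 is expected to give about 3000 nM, with a range from 1000 nM to 10000 nM, and most likely to be reported again as a limit.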

Compound 4, half-maximal inhibitory concentration: 192 nM
Estimate against measurement, compound 4: 16-fold (1.19 log units) above; measured number below the stated range.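

In this assay, among these compounds, hydroxymethyl in place of hydroxy on a saturated chain carbon, four bonds along the chain from an aromatic carbon, gives an at least 10-fold lower number from compound 3 to compound 4 (1.01 log units; beyond the scatter), and this is the first readable step. The position is therefore sensitive to a small change in the chain that ends in a hydroxyl, since the shared core, the isobutyl and methyl groups and the naphthylmethyl arm stay the same in this pair. The true size of the step remains open, and its printed size is only a lower bound because one end of it is a limit and not a number: the limit of > 2000 nM in this assay, at which 1 of the 4 values shown sits.

Whether a longer chain would lower the number further or reverse the gain is open, as is whether the end of the chain must be a hydroxyl or could be an amine or a carboxylic acid. Steps involving the sulfur-linked compound 1 and compound 2 cannot be read, so the effect of sulfur in this chain on the number stays unknown.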